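A few compounds are considered here, and "the series" means these few. Any claim that something is new, unique, unknown or untested is made for them only; others in the source may bear on it.

Working notes on the series.

Compound 1 `O=C(Nc1ccccc1C(F)(F)F)C1CCc2ccccc2N1` carries the shared core with hydrogen on the ring nitrogen. In a functional assay on HCT-15 cells (Homo sapiens) for cytotoxicity, read by sulforhodamine B assay, with a stated time of 72 h (a lower number here means a stronger inhibitor of growth, a higher number a weaker inhibitor of growth), compound 1 gives 40400 nM. Compound 2 `O=C(Nc1ccccc1C(F)(F)F)C1CCc2ccccc2N1C(=O)c1ccccc1` is the benzoyl analogue, and in this assay compound 2 gives 6500 nM. The change between them is hydrogen in place of benzoyl on a nitrogen on an aromatic ring in a ring; the step is a 6.2-fold higher number from compound 2 to compound 1 (0.79 log units; beyond the scatter). Compound 3 `O=C(Nc1ccccc1O)C1CCc2ccccc2N1C(=O)c1ccccc1` keeps the benzoyl and differs from compound 2 by hydroxy in place of trifluoromethyl on an aromatic carbon; in this assay compound 3 gives 3830 nM, and the step is a 1.7-fold lower number from compound 2 to compound 3 (0.23 log units; within the scatter), so compound 2 and compound 3 cannot be ranked against each other. Against compound 1 the values of compound 3 and compound 1 stand far apart, with compound 1 giving the higher number.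

Compound 4 `O=C(Nc1ccccc1O)C1CCc2ccccc2N1` is not yet measured. It differs from compound 3 by hydrogen in place of benzoyl on a nitrogen on an aromatic ring in a ring, the same change as from compound 2 to compound 1, on a core that differs by hydroxy in place of trifluoromethyl on an aromatic carbon; the two place descriptions read the same word for word. The expected step in this assay is a 6.0-fold higher number from compound 3 to compound 4 (0.78 log units; beyond the scatter), set beside a 6.2-fold higher number from compound 2 to compound 1 (0.79 log units; beyond the scatter), since removal of the benzoyl on the other core raised the number from compound 2 to compound 1 by that amount, and nothing in the three values suggests the hydroxy core would respond differently. Compound 4 is therefore expected to give about 23000 nM in this assay, with a range estimated from 9000 nM to 60000 nM.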

Compound 4, concentration for 50% growth inhibition: 5610 nM
The estimate for compound 4 lay 4.1-fold (0.61 log units) above the measured number; measured number outside the range, below it.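

On the core carrying hydroxy, hydrogen in place of benzoyl gives a 1.5-fold higher number from compound 3 to compound 4 (0.17 log units; within the scatter), so this pair cannot be ranked, and the step seen on the core carrying trifluoromethyl does not carry over in this assay: the same change on two cores in this assay, a 6.2-fold higher number (0.79 log units; beyond the scatter) from compound 2 to compound 1 and a 1.5-fold higher number (0.17 log units; within the scatter) from compound 3 to compound 4, 4.2-fold (0.63 log units) apart, beyond the scatter of two such steps

Read the other way, hydroxy in place of trifluoromethyl gives a 7.2-fold lower number from compound 1 to compound 4 (0.86 log units; beyond the scatter) when the ring nitrogen bears hydrogen, whereas the same change on the benzoyl compounds stays within the scatter, so its size also depends on the core: the same change on two cores in this assay, a 1.7-fold lower number (0.23 log units; within the scatter) from compound 2 to compound 3 and a 7.2-fold lower number (0.86 log units; beyond the scatter) from compound 1 to compound 4, 4.2-fold (0.63 log units) apart, beyond the scatter of two such steps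

These two gaps are a single result seen from two sides, resting on four values; they show that the two changes do not add independently in these compounds, but they do not show why, nor whether this holds beyond these four compounds.

As far as these compounds go, whether a methoxy group or an amine in place of the hydroxy would follow the hydroxy or the trifluoromethyl pattern, with and without the benzoyl, stays open. From the compounds shown here alone, it is also open whether an acetyl group on the ring nitrogen would match the benzoyl on either core.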